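A few compounds are considered here, and "the series" means these few. Any claim that something is new, unique, unknown or untested is made for them only; others in the source may bear on it.

Measured compounds:
Compound 1 `COc1cc(/C=C/C(=O)c2cccc(-n3cc(-c4ccccc4)[nH]c3=O)c2)cc(OC)c1OC` — 1520 nM
Compound 2 `COc1ccc(-c2cn(-c3cccc(C(=O)/C=C/c4ccc(O)c(OC)c4)c3)c(=O)[nH]2)cc1` — 3960 nM

Both compounds were tested in a functional assay on UACC-62 cells (Homo sapiens) for inhibition; a higher number here means a weaker inhibitor of growth, a lower number a stronger inhibitor of growth. Compound 2 has the highest number of the two; its nearest neighbour is compound 1, whose number is lower by a gap that lies beyond the usual scatter of repeated measurements.

Compound 3 `COc1ccc(-c2cn(-c3cccc(C(=O)/C=C/c4cc(OC)c(OC)c(OC)c4)c3)c(=O)[nH]2)cc1` has not yet been measured. It differs from compound 2 in one place: 3,4,5-trimethoxyphenyl in place of 4-hydroxy-3-methoxyphenyl on a double-bonded chain carbon bound to a double-bonded chain carbon. The rest of the structure, including the methoxy-bearing phenyl on the shared core, is kept from compound 2. Compound 1 already carries the 3,4,5-trimethoxyphenyl on the same chain carbon, and in this assay compound 1 gives 1520 nM, so a move toward a lower number is the expectation here. The expected step of a 2.5-fold lower number from compound 2 to compound 3 (0.39 log units; beyond the scatter) is modest, roughly matching the gap between the two measured compounds. For compound 3 the estimate in this assay is 1600 nM, with a range from 600 nM to 4500 nM.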

Compound 3, concentration for 50% growth inhibition: 2060 nM
Beside the measured number, compound 3's estimate is 1.3-fold (0.11 log units) below it; low and high end bracket the measured number.
By their numbers in this assay, from the lowest: compounds 1, 3 and 2 (each within the scatter of the next, the first and the last beyond it).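

In this assay, 3,4,5-trimethoxyphenyl in place of 4-hydroxy-3-methoxyphenyl on this chain carbon gives a 1.9-fold lower number from compound 2 to compound 3 (0.28 log units; within the scatter), which lies within the scatter, so these compounds do not show that giving up the hydrogen-bond donor of the leaving group matters for growth inhibition. Methoxy in place of hydrogen on an aromatic carbon gives a 1.4-fold higher number from compound 1 to compound 3 (0.13 log units; within the scatter), also within the scatter, so neither single change can be told apart from repeat-measurement noise. Nothing available here bears on how either change acts on these cells.

Still open, as far as these compounds go, is whether a phenyl carrying an amine or a carboxylic acid on this chain carbon would shift the number beyond the scatter. Also open, from the compounds shown here alone, is whether an ethoxy or a chlorine in place of that methoxy would do so.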